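The compounds below may be only part of what the source reports. "The series", "measured", "known", "first", "only" and "open" are said of these compounds alone.

Compound 1 `Cn1c(-c2ccc(C#N)cc2)cnc1NC(=O)c1ccc(F)cc1` — > 50000 nM
Compound 2 `Cn1c(-c2ccc([N+](=O)[O-])cc2)cnc1NC(=O)c1ccc(F)cc1` — > 50000 nM
Compound 3 `COc1ccc(-c2cnc(NC(=O)c3ccc([N+](=O)[O-])cc3)n2C)cc1` — > 100000 nM

In a toxicity assay on THP-1 cells (Homo sapiens) for inhibition (on this read-out lower numbers stand for higher toxicity in this test and higher numbers for lower toxicity in this test), compound 1 gives > 50000 nM, which is a limit of the assay and not a number. In this assay compound 2 gives > 50000 nM, likewise a limit. In this assay compound 3 gives > 100000 nM, again a limit and not a number.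

Compound 2 and compound 1 differ by one change, (cyano in place of nitro on an aromatic carbon). The step it made, a step that the two limits leave unreadable from compound 2 to compound 1, cannot be read because both values sit at the limit of > 50000 nM in this assay, at which 2 of the 3 values shown sit. How the core of compound 3 differs from that of compound 2 is not broken down here.

Compound 4 `COc1ccc(-c2cnc(NC(=O)c3ccc(C#N)cc3)n2C)cc1` has not been measured in this assay. It differs from compound 3 by cyano in place of nitro on an aromatic carbon, the same change, at a place described in the same words. For compound 3 to compound 4 a step of a number no higher from compound 3 to compound 4 (the limit leaves the size open) is expected, resting on compound 2 and compound 1, whose step that the two limits leave unreadable from compound 2 to compound 1 is not readable, and on compound 3, whose value > 100000 nM sits at the limit of > 100000 nM in this assay, at which 1 of the 3 values shown sits. Compound 4 is therefore estimated at 100000 nM, between 50000 nM and 200000 nM, and is expected to be reported again only as a limit.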

Compound 4, half-maximal cytotoxic concentration: > 100000 nM
Compound 4 ended at the assay's limit; the forecaster's own chance of this, stated with the estimate: 90%; the middle value sits exactly at the limit.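

Compound 3 and compound 4 both stand at a limit and not at a number in this assay, and no step between them can be read: the limit of > 100000 nM in this assay, at which 2 of the 4 values shown sit.

The compounds shown leave open whether cyano in place of nitro on an aromatic carbon changes the read-out at all, and at what concentration, if any, each of the four compounds turns toxic.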